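The source may hold more compounds than are shown below. What is called first, only, known or untested is meant among the compounds shown, and "the series" means these compounds.

In a functional assay on CHO cells for agonist activity at sphingosine 1-phosphate receptor 5 (Homo sapiens), read by GTPgammaS binding (on this read-out lower numbers stand for an effect already at smaller amounts and higher numbers for an effect only at larger amounts of compound), compound 1, `Cc1ccccc1-c1noc(-c2ccc(C3CCCCC3)cc2)n1`, gives 266 nM. Compound 2, `Cc1cc(CCC(=O)O)ccc1-c1noc(-c2ccc(OC(C)C)c(F)c2)n1`, gives 530 nM in this assay. The two values lie within the usual scatter of one another, so the numbers shown do not set compound 2 apart from compound 1; it simply sits at the far end of the pair of readings. Compound 3, `Cc1cc(CCC(=O)O)ccc1-c1noc(-c2ccc(OC(C)C)c(C#N)c2)n1`, has not yet been measured. It differs from compound 2 in one place: cyano in place of fluoro on an aromatic carbon. For the measured compounds named here, no measured pair in this set shows what such an exchange does, so the expectation for compound 3 rests on the structural change alone. A step of moderate size toward lower numbers is expected in this assay, a 2.1-fold lower number from compound 2 to compound 3 (0.33 log units; beyond the scatter), though a result within the scatter would not surprise. Compound 3 is therefore estimated at 250 nM in this assay, with a range from 60 nM to 1000 nM.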

Compound 3, half-maximal effective concentration: 6.5 nM
Beside the measured number, compound 3's estimate is 38-fold (1.59 log units) above it; the whole stated range lies above it.
By their numbers in this assay, from the lowest: compound 3; then compounds 1 and 2 (each within the scatter of the next).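

In this assay, cyano in place of fluoro on the aromatic carbon ortho to an isopropoxy group gives an 82-fold lower number from compound 2 to compound 3 (1.91 log units; beyond the scatter), so this one position can shift the read-out by a wide margin. No earlier pair had shown what any exchange does here, and this one is small in its count of atoms, with the entering cyano bringing a triple bond and a hydrogen-bond acceptor that the fluoro lacks. No measurement here accounts for the size of the step.

From the compounds shown here alone, whether the same shift would follow from another group on this carbon, such as a chlorine atom, a methoxy group or an amide, stays open. So does whether cyano would have the same effect if a longer chain stood in place of the isopropoxy group.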